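Second methoxy on a scaffold without measurable activity

A few compounds are considered here, and "the series" means these few. Any claim that something is new, unique, unknown or untested is made for them only; others in the source may bear on it.

compound 1: `CCOC(=O)C12C(=O)OCC=C1COC2c1ccccc1` – > 1000000 nM
compound 2: `CCOC(=O)C12C(=O)OCC=C1COC2c1ccc(OC)cc1` – > 1000000 nM

In a functional assay on QGY cells (Homo sapiens) for cytotoxicity, read by MTT assay (on this read-out higher numbers stand for weaker inhibition and lower numbers for stronger inhibition), compound 1 gives > 1000000 nM, a limit of the assay rather than a number. Compound 2 gives > 1000000 nM in this assay, again a limit. Compound 2 therefore stands at the ceiling of what this assay reports, and nothing distinguishes it from compound 1 on the numbers shown. Going by the values given here, the only measured step, a step that the two limits leave unreadable from compound 1 to compound 2, cannot be sized, as the limit of > 1000000 nM in this assay, at which 2 of the 2 values shown sit, makes plain.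

Compound 3 is `CCOC(=O)C12C(=O)OCC=C1COC2c1ccc(OC)c(OC)c1`. It differs from compound 2 by methoxy in place of hydrogen on an aromatic carbon. Among the compounds with values here, the single measured step bears on this change, being the same kind of substitution on the same ring, yet it gives no readable size in either direction. Nothing in the measured compounds points to a change beyond the scatter.

Compound 3 is thus expected to remain at or near the ceiling of this assay, with an estimate of 1000000 nM (range 300000 nM to 3000000 nM). The step this estimate implies, a number no higher from compound 2 to compound 3 (the limit leaves the size open), is expected to be essentially none, and most likely the assay reports only another limit.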

Compound 3, half-maximal inhibitory concentration: > 1000000 nM
Compound 3: no number, only a limit (the forecaster's own chance of this, stated with the estimate: 85%); the middle value sits exactly at the limit.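

Compound 2 and compound 3 both end at a limit of the assay rather than a number, so no new step can be read between them in this assay: the limit of > 1000000 nM in this assay, at which 3 of the 3 values shown sit.

The compounds shown leave open whether any substitution on the shared core would give a readable value in this assay, and how large the effect of either added methoxy is.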